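This account rests on a few compounds, and the source may have more. Where it says the series, first, only, none or still open, it means among the compounds named here.

Of the compounds shown here, three that share a core have been measured in a functional assay on HeLa cells (Homo sapiens) for cytotoxicity, read by WST assay, with a stated time of 48 h; a lower number here means a stronger inhibitor, a higher number a weaker inhibitor. Compound 1 `COc1cccc([C@@H]2OC[C@H]([C@@H](O)c3ccc(OC)c(OC)c3)C[C@H]2C/C=C/c2ccc(OC)c(OC)c2)c1` gives 30100 nM, compound 2 `Oc1ccccc1/C=C/C[C@H]1C[C@@H]([C@@H](O)c2ccccc2)CO[C@@H]1c1ccccc1` gives 21800 nM, and compound 3 `COc1ccc([C@H](O)[C@H]2CO[C@H](c3ccc(OC)c(OC)c3)[C@@H](C/C=C/c3ccc(OC)c(OC)c3)C2)cc1` gives 46000 nM. Compound 2 and compound 1 lie within the scatter of each other, while compound 3 has a higher number than compound 2, a gap beyond the scatter.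

Compound 4 `COc1ccc(/C=C/C[C@H]2C[C@@H]([C@@H](O)c3ccccc3)CO[C@@H]2c2ccccc2)cc1` has not yet been measured. It departs from compound 2 in one place: 4-methoxyphenyl in place of 2-hydroxyphenyl on a double-bonded chain carbon bound to a double-bonded chain carbon. In this change, 4-methoxyphenyl stands in place of 2-hydroxyphenyl on a double-bonded chain carbon bound to a double-bonded chain carbon.

For the measured compounds named here, no two measured compounds differ in only one place, so no measured step shows directly what this change does in this assay. The available guide is indirect. Compound 1, at 30100 nM, and compound 3, at 46000 nM, also carry methoxy groups, and neither has a lower number than compound 2. The expectation is therefore a small move toward a higher number, or none beyond the scatter. The estimated change is a 1.4-fold higher number from compound 2 to compound 4 (0.14 log units; within the scatter). For compound 4 the expected value is 30000 nM, with an estimated range from 12000 nM to 70000 nM.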

Compound 4, half-maximal inhibitory concentration: 8300 nM
Beside the measured number, compound 4's estimate is 3.6-fold (0.56 log units) above it; measured number below the stated range.
By their numbers in this assay, from the lowest: compound 4; then compounds 2, 1 and 3 (each within the scatter of the next, the first and the last beyond it).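

In this assay, 4-methoxyphenyl in place of 2-hydroxyphenyl on a double-bonded chain carbon bound to a double-bonded chain carbon gives a 2.6-fold lower number from compound 2 to compound 4 (0.42 log units; beyond the scatter) and is the first single-place change that can be read among these compounds. The step lies beyond the scatter, so the group at this place does affect the number in this assay, although the size of the step is modest. The 2-hydroxyphenyl group is also not needed to reach this level of activity, as the 4-methoxyphenyl group that replaces it has no hydrogen-bond donor, and the data offer no measured explanation for the step.

This single step changes both the oxygen substituent and its place on the aromatic ring, so it leaves open which of the two matters, a question that a 4-hydroxyphenyl or a 2-methoxyphenyl group at this place would help to settle. Also open, from the compounds shown here alone, is whether the same change would give a step of similar size on the more heavily substituted rings of compound 1 and compound 3.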